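The compounds below may be only part of what the source reports. "The series", "measured", "known", "first", "only" and "open" are said of these compounds alone.

Three members of this set have been measured in a functional assay on CRL2813 cells (Homo sapiens) for cytotoxicity, read by sulforhodamine B assay, with a stated time of 5 days; on this read-out higher numbers stand for weaker inhibition and lower numbers for stronger inhibition. Compound 1 `O=C(Nc1cccc(C(F)(F)F)c1)N[C@H]1CC[C@@H](Oc2ccc(F)cc2)CC1` gives 2600 nM, and compound 3 `O=C(Nc1cccc(C(F)(F)F)c1)N[C@H]1CCC[C@H](Oc2ccc(C(F)(F)F)cc2)C1` gives 3800 nM. These two values lie within the usual scatter of each other, so no order is read between compound 1 and compound 3. Compound 2 `O=C(Nc1ccc(Cl)cc1)N[C@H]1CC[C@H](Oc2ccc(F)cc2)CC1` stands apart from them. In this assay compound 2 returns only a limit, > 20000 nM, and not a number. From the compounds shown here alone, compound 2 thus sits at the limit of > 20000 nM in this assay, at which 1 of the 3 values shown sits, and how far beyond that limit its true value lies is unknown.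

Compound 4 `O=C(Nc1ccccc1)N[C@H]1CC[C@H](Oc2ccc(F)cc2)CC1` has not yet been measured. It differs from compound 2 by hydrogen in place of chloro on an aromatic carbon, while the shared core, the urea and the fluorophenyl ether are kept. Among the compounds with values here, no step between two measured compounds is available here, so the size of this change cannot be read from a measured pair. The expectation for compound 4 therefore rests on compound 2 alone. The step from compound 2 to compound 4 is expected to stay within the scatter, a step that the limit leaves unreadable from compound 2 to compound 4. Compound 4 is estimated at 25000 nM, with a range from 8000 nM to 80000 nM, and it is expected that the assay will again most likely report only a limit.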

Compound 4, half-maximal inhibitory concentration: 20000 nM
Beside the measured number, compound 4's estimate is 1.3-fold (0.10 log units) above it; the range from low to high includes it.
By their numbers in this assay, from the lowest: compounds 1 and 3 (each within the scatter of the next); then compound 4.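

In this assay the change from 4-chlorophenyl to phenyl, hydrogen in place of chloro on an aromatic carbon para to a large group, gives a number no higher from compound 2 to compound 4 (the limit leaves the size open). Within the data shown here, this is the first reading of this position in the set, since no earlier pair of compounds differed there in one place only. Compound 4 gives 20000 nM, so the compound without chloro returns an actual number, and that number still lies at the weak end of what is shown, which means that taking chloro away brings no readable gain in inhibition. From the compounds shown here alone, compound 2 returns only a limit and not a number, so the size of this step stays open: the limit of > 20000 nM in this assay, at which 1 of the 4 values shown sits.

The compounds shown leave open whether another group on this aromatic carbon, such as an amine, a nitrile or a carboxylic acid, would move the number away from that weak end. They also leave open how much of the stronger values of compound 1 and compound 3 belongs to the aromatic group on the urea and how much to the rest of the structure, as neither differs from compound 4 in one place only.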